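A few compounds are considered here, and "the series" means these few. Any claim that something is new, unique, unknown or untested is made for them only; others in the source may bear on it.

Measured so far in a functional assay on isolated protein for inhibition of Glucose-dependent insulinotropic receptor (Homo sapiens), read by HTRF and cAMP accumulation; on this read-out lower numbers stand for an effect already at smaller amounts and higher numbers for an effect only at larger amounts of compound:
- compound 1 `Cc1nc(S(C)(=O)=O)ccc1Oc1ncnc(OC2CCN(C(=O)OC(C)C)CC2)c1F`: 21 nM
- compound 2 `Cc1nc(S(C)(=O)=O)ccc1Oc1ncnc(OC2CCN(C(=O)C(C)(C)F)CC2)c1F`: 76.3 nM
- compound 3 `CCC(F)(F)C(=O)N1CCC(Oc2ncnc(Oc3ccc(S(C)(=O)=O)nc3C)c2F)CC1`: 17.4 nM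

Compound 3 gives the lowest number of the three in this assay; its nearest neighbour is compound 1 (a 1.2-fold lower number from compound 1 to compound 3 (0.08 log units; within the scatter)), its furthest compound 2 (a 4.4-fold lower number from compound 2 to compound 3 (0.64 log units; beyond the scatter)).

Compound 4 `Cc1nc(S(C)(=O)=O)ccc1Oc1ncnc(OC2CCN(C(=O)C3(F)CCC3)CC2)c1F` is not yet measured. Against compound 3 the change is a group of 5 heavy atoms (4 carbon, 1 fluorine; one four-membered non-aromatic ring of carbon only) in place of a group of 5 heavy atoms (3 carbon, 2 fluorine; no ring), on a carbonyl carbon.

Two of the measured steps concern the same carbonyl carbon. From compound 1 to compound 3 the exchange of isopropoxy for 1,1-difluoropropyl stayed within the scatter (a 1.2-fold lower number from compound 1 to compound 3 (0.08 log units; within the scatter)). From compound 2 to compound 3 the exchange of 1-fluoro-1-methylethyl for 1,1-difluoropropyl gave a 4.4-fold lower number from compound 2 to compound 3 (0.64 log units; beyond the scatter). For the measured compounds named here, compound 4 carries, like compound 2, a group with one fluorine on the carbon attached to the carbonyl, but closed into a four-membered ring; no measured pair shows such a ring. A modest rise in number from compound 3 is therefore expected, smaller than the step seen with compound 2, and compound 4 is estimated at 35 nM (range 12 nM to 100 nM), which means an expected step of a 2.0-fold higher number from compound 3 to compound 4 (0.30 log units; within the scatter).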

Compound 4, half-maximal effective concentration: 24.7 nM
Estimate against measurement, compound 4: 1.4-fold (0.15 log units) above; measured number inside the range.
By their numbers in this assay, from the lowest: compounds 3, 1 and 4 (each within the scatter of the next); then compound 2.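

In this assay, the four-membered carbon ring with one fluorine on the carbonyl carbon stays within the scatter of the open-chain 1,1-difluoropropyl group, with a 1.4-fold higher number from compound 3 to compound 4 (0.15 log units; within the scatter), and of the isopropoxy group, with a 1.2-fold higher number from compound 1 to compound 4 (0.07 log units; within the scatter). The same ring group separates from 1-fluoro-1-methylethyl, which also carries one fluorine, with a 3.1-fold lower number from compound 2 to compound 4 (0.49 log units; beyond the scatter), so among these compounds a single fluorine does not by itself go with the higher number of compound 2. Nothing available accounts for these steps.

Still open, from the compounds shown here alone, is how the smaller 1-fluorocyclopropyl or the larger 1-fluorocyclopentyl group would read on the same carbonyl carbon. The plain cyclobutyl group, without fluorine, would show what the fluorine of compound 4 contributes.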